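Methoxy to hydrogen on the fused ring system of compound 1

The source may report more compounds than this note shows. Statements on the series, on what has been measured and on what is new or still open speak of the compounds shown alone.

Compound 1 `COc1ccc(Cl)c(-c2nnc3sc(Cc4c[nH]c5ccc(OC)cc45)nn23)c1` and compound 2 `COc1ccc2[nH]cc(Cc3nn4c(-c5ccoc5C)nnc4s3)c2c1` share one core and have been read in a functional assay on the whole organism (strain Wistar Albino) for inhibition, with Rattus norvegicus as the target, read by paw edema, with a stated time of 4 h, at a dose of 20 mg/kg; a lower number here means less inhibition, a higher number more inhibition at the dose given (going by the name of the read-out). In this assay compound 1 gives 33.9% and compound 2 gives 30.8%. Compound 1 stands at the top of these two numbers, but only by the step of a number 3.1 percentage points lower from compound 1 to compound 2 (within the scatter), which puts 2-methylfuran-3-yl in place of 2-chloro-5-methoxyphenyl on an aromatic carbon and is within the scatter, so no order between the two compounds follows from it.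

Compound 3 `COc1ccc(Cl)c(-c2nnc3sc(Cc4c[nH]c5ccccc45)nn23)c1` is not yet measured. It differs from compound 1 in one place: hydrogen in place of methoxy on an aromatic carbon. Within the data shown here, no measured step bears on this change; the single step recorded, a number 3.1 percentage points lower from compound 1 to compound 2 (within the scatter), touches a different part of the molecule and leaves the methoxy on the fused ring system untouched. Without a guide from the data, the expectation for compound 3 is a number close to that of compound 1, with no step beyond the scatter, a number 1.9 percentage points lower from compound 1 to compound 3 (within the scatter). The estimate for compound 3 in this assay is therefore 32%, expected to lie between 20% and 44%.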

Compound 3, a percentage reported as inhibition, in the whole organism at one dose (the size of the read-out at that dose, not a potency): 34.7%
For compound 3 the middle estimate is 2.7 percentage points below the measured one; the range from low to high includes it.
By their numbers in this assay, from the lowest: compounds 2, 1 and 3 (each within the scatter of the next).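

Hydrogen in place of methoxy on this aromatic carbon of the fused system gives, in this assay, a number 0.8 percentage points higher from compound 1 to compound 3 (within the scatter) and so puts a reading on a place that compound 1 and compound 2 left unchanged, their single difference lying at the 2-chloro-5-methoxyphenyl group. For this position, the methoxy, with its 2 heavy atoms and 1 hydrogen-bond acceptor, can give way to hydrogen with no step beyond the scatter at this one dose, at least with 2-chloro-5-methoxyphenyl on the shared core. No supporting data accompany this result that could account for it.

Open is how an amine, a carboxylic acid or a longer chain such as butoxy on this same aromatic carbon would read in this assay: the compounds shown carry only methoxy and hydrogen there. Also open, from the compounds shown here alone, is whether hydrogen in place of methoxy gives a step of similar size with 2-methylfuran-3-yl on the shared core, and whether the step stays within the scatter at other doses or other times.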